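A few compounds are considered here, and "the series" means these few. Any claim that something is new, unique, unknown or untested is made for them only; others in the source may bear on it.

Measured compounds:
Compound 1, `CC(=O)OCc1ccc2oc(=O)c(C(=O)Sc3cccc(Cl)c3)cc2c1`, gives 65.8% in a functional assay on HT-1080 cells (Homo sapiens), read by transwell migration, with a stated time of 24 h, tested at 1 uM; on this read-out higher numbers stand for a weaker effect at the one concentration tested and lower numbers for a stronger effect.
Compound 2, `CC(=O)OCc1ccc2oc(=O)c(C(=O)Sc3cccc(Br)c3)cc2c1`, gives 70.9% in this assay.
Compound 3, `NCc1ccc2oc(=O)c(C(=O)Oc3cccc(Cl)c3)cc2c1`, gives 86.6% in this assay.

Compound 1 and compound 2 share one core, while compound 3 is built on another; the difference between the two cores is not broken down here. A fourth member, compound 4, `NCc1ccc2oc(=O)c(C(=O)Oc3cccc(Br)c3)cc2c1`, has not yet been measured.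

Within the first pair the single change is bromo in place of chloro on an aromatic carbon, and the step that went with it was a number 5.1 percentage points higher from compound 1 to compound 2 (within the scatter), so the two numbers cannot be told apart. Compound 3 stands highest of the three measured numbers, and its distance to compound 2 and to compound 1 lies beyond the scatter in both cases. Among the measured compounds shown here, the change from compound 3 to compound 4 is bromo in place of chloro on an aromatic carbon; it is the same change as the one between compound 1 and compound 2, made at the same place on the ring.

Because a number 5.1 percentage points higher from compound 1 to compound 2 (within the scatter) lay within the scatter, the step on the second core is expected to be small as well, estimated at a number 2.4 percentage points higher from compound 3 to compound 4 (within the scatter). This rests on one pair only, and nothing shows how the second core answers to this change. Compound 4 is therefore expected to give about 89%, with an estimated range from 78% to 99%.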

Compound 4, a percentage reported as activity, at one concentration (the size of the read-out at that concentration, not a potency): 79.3%
The estimate for compound 4 lay 9.7 percentage points above the measured number; the range from low to high includes it.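

In this assay, bromo in place of chloro on an aromatic carbon of the core of compound 3 went with a number 7.3 percentage points lower from compound 3 to compound 4 (within the scatter), so on this core too the two numbers cannot be told apart. Set beside the step on the core of compound 1, the change reads alike on both cores as far as these measurements can resolve, and the opposite directions of the two steps carry no weight: the same change on two cores in this assay, a number 5.1 percentage points higher (within the scatter) from compound 1 to compound 2 and a number 7.3 percentage points lower (within the scatter) from compound 3 to compound 4, 12.4 percentage points apart, within the scatter of two such steps

Among the compounds shown here, this shows that, in these two pairs, going from 3-chlorophenyl to 3-bromophenyl left no step that could be read on either core, which is consistent with the change carrying over from one core to the other; it does not show that the change is without effect in general, that the two cores truly answer alike, or that a small real difference is absent, as only two pairs at a single concentration are available and scatter of this size could hide such a difference.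

The compounds shown leave open how a fluoro, iodo, methyl, methoxy or nitrile group would read in the same place on the ring. They also leave open whether a halogen elsewhere on that ring, or an unsubstituted phenyl, would behave as these pairs do on either core.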